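The source may report more compounds than this note shows. Statements on the series, on what has been measured and on what is new or still open speak of the compounds shown alone.

Measured in a functional assay on HCC827 cells (Homo sapiens) for inhibition, read by fluorescence, with a stated time of 72 h; a higher number here means a weaker inhibitor of growth, a lower number a stronger inhibitor of growth:
- compound 1 `CC(C)CCn1cnc2c(Nc3ccc(Cl)cc3)nc(N[C@H]3CC[C@H](N)CC3)nc21`: 10200 nM
- compound 2 `CC(C)=CCn1cnc2c(Nc3cccc(Cl)c3)nc(N[C@H]3CC[C@H](N)CC3)nc21`: 13500 nM
- compound 3 `CC(C)CCn1cnc2c(NCc3cccc(Cl)c3)nc(N[C@H]3CC[C@H](N)CC3)nc21`: 16700 nM

Compound 3, at 16700 nM, stands within the scatter of both other compounds, so the three values do not separate. The next compound to be tested is compound 4 `CC(C)CCn1cnc2c(Nc3cccc(Cl)c3)nc(N[C@H]3CC[C@H](N)CC3)nc21`, which carries 3-chlorophenyl in place of 3-chlorobenzyl on a nitrogen on an aromatic ring.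

Within the data shown here, one measured step bears directly on this change. It is the step with 3-chlorobenzyl in place of 4-chlorophenyl on that same nitrogen, a 1.6-fold higher number from compound 1 to compound 3 (0.21 log units; within the scatter). It does not match the present change exactly, since the group it starts from is 4-chlorophenyl and not 3-chlorophenyl. Compound 2 offers further support, as it already bears 3-chlorophenyl on this nitrogen and gives 13500 nM, although it does not share the rest of compound 3. With so small a step from compound 1 and no value apart from the others for compound 2, no change beyond the scatter is expected in this assay. The expected step, a 1.4-fold lower number from compound 3 to compound 4 (0.14 log units; within the scatter), is an estimate that stays within the scatter. For compound 4 the estimated value is 12000 nM, with an expected range of 6000 nM to 24000 nM.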

Compound 4, concentration for 50% growth inhibition: 10300 nM
Compound 4: the middle estimate sits 1.2-fold (0.07 log units) above what was measured; low and high end bracket the measured number.
By their numbers in this assay, from the lowest: compounds 1, 4, 2 and 3 (each within the scatter of the next).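

In this assay the direct exchange on a nitrogen on an aromatic ring, 3-chlorophenyl in place of 3-chlorobenzyl, gives a 1.6-fold lower number from compound 3 to compound 4 (0.21 log units; within the scatter) and so shows that this change, read with all else held the same, does not separate the two groups. The same position can now also be read for the two chlorophenyl groups, as 3-chlorophenyl in place of 4-chlorophenyl gives a 1.0-fold higher number from compound 1 to compound 4 (0.00 log units; within the scatter) and leaves the two compounds indistinguishable in this read-out. The chain, on a saturated chain carbon bound to an aromatic nitrogen, can be read with the aryl group held constant for the first time, and isobutyl in place of 2-methylprop-1-en-1-yl gives a 1.3-fold lower number from compound 2 to compound 4 (0.12 log units; within the scatter), so neither place has yet produced a step beyond the scatter among these compounds.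

As far as these compounds go, it remains open whether an amine or a carboxylic acid on the aromatic ring, or a longer chain in place of isobutyl, would give a step beyond the scatter. No independent measurement bears on these results, and they remain unexplained.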